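A few compounds are considered here, and "the series" means these few. Any claim that something is new, unique, unknown or untested is made for them only; others in the source may bear on it.

In a functional assay on PC-3 cells (Homo sapiens) for antiproliferative activity, read by MTT assay, with a stated time of 48 h (a lower number here means a stronger inhibitor, a higher number a weaker inhibitor), compound 1 (`COc1ccc(CN(C(=O)Cn2cc(COc3cc(=O)oc4ccccc34)nn2)c2cc(OC)c(OC)c(OC)c2)cc1`) gives 5140 nM and compound 2 (`COc1ccc(CN(C(=O)Cn2cc(COc3ccc4ccc(=O)oc4c3)nn2)c2cc(OC)c(OC)c(OC)c2)cc1`) gives 860 nM, while compound 3 (`COc1ccc(CN(C(=O)Cn2cc(COc3ccc4c(C)cc(=O)oc4c3)nn2)c2cc(OC)c(OC)c(OC)c2)cc1`) gives 340 nM as the lowest of the three numbers. The next structure is compound 4 (`COc1ccc(CN(C(=O)Cn2cc(COc3ccccc3)nn2)c2cc(OC)c(OC)c(OC)c2)cc1`), still unmeasured. For the measured compounds named here, the change is a group of 6 heavy atoms (6 carbon; one six-membered aromatic ring of carbon only) in place of a group of 12 heavy atoms (10 carbon, 2 oxygen; one six-membered aromatic ring of carbon only, one six-membered aromatic ring with 1 hetero atom), on an oxygen on a saturated carbon and no measured step makes this exchange. Phenyl enters on an oxygen on a saturated carbon, and the six-membered aromatic ring with 1 hetero atom leaves with the outgoing group.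

The nearest evidence is the exchange of one group for another on the same oxygen, with a 6.0-fold lower number from compound 1 to compound 2 (0.78 log units; beyond the scatter) as a modest step and a 15-fold lower number from compound 1 to compound 3 (1.18 log units; beyond the scatter) as a large one. Methyl in place of hydrogen on an aromatic carbon gives a 2.5-fold lower number from compound 2 to compound 3 (0.40 log units; beyond the scatter) as a further modest step. All three lie beyond the scatter, so the number in this assay follows this group across these compounds, although none of them loses a ring.

A higher number is expected for compound 4, modest to large in size, because compound 3 at 340 nM is the lowest so far. The estimated step is a 7.4-fold higher number from compound 3 to compound 4 (0.87 log units; beyond the scatter) with wide uncertainty. The expected value for compound 4 is 2500 nM (estimated range 600 nM to 10000 nM).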

Compound 4, half-maximal inhibitory concentration: 45300 nM
Beside the measured number, compound 4's estimate is 18-fold (1.26 log units) below it, and the stated range ends below it.
By their numbers in this assay, from the lowest: compound 3; then compound 2; then compound 1; then compound 4.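

In this assay phenyl on an oxygen on a saturated carbon gives the highest number of the four compounds, with a 130-fold higher number from compound 3 to compound 4 (2.12 log units; beyond the scatter) and a 53-fold higher number from compound 2 to compound 4 (1.72 log units; beyond the scatter) as large steps and an 8.8-fold higher number from compound 1 to compound 4 (0.95 log units; beyond the scatter) as a modest one. The earlier compounds shown here showed only exchanges among groups that all carry the six-membered aromatic ring with 1 hetero atom, whereas this change removes that ring, both oxygens of the group and the double bond outside aromatic rings, and all three groups that carry them give lower numbers than phenyl, however they are attached to the oxygen. How much of the step belongs to the ring and how much to the other departing atoms cannot be separated here, and nothing available explains the size of these steps.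

Naphthyl on the same oxygen would keep a second aromatic ring without the oxygens, and so would test whether the ring alone accounts for the lower numbers. Also open, on these data alone, is whether a methoxy group, an amine or a carboxylic acid on the phenyl ring of compound 4 would recover any of the lost ground.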